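A few compounds are considered here, and "the series" means these few. Any claim that something is new, unique, unknown or untested is made for them only; others in the source may bear on it.

Measured compounds in a functional assay on THP-1 cells (Homo sapiens) for inhibition; a lower number here means a stronger inhibitor, a higher number a weaker inhibitor:
- compound 1 `O=C(CN1CC=CC[C@H](NC(=O)c2cccc(Cl)c2)C1=O)N[C@H]1CC(=O)OC1O`: 383 nM
- compound 2 `O=C(CN1CC=CC[C@H](NC(=O)c2cc3ccccc3s2)C1=O)N[C@H]1CC(=O)OC1O`: 712 nM
- compound 3 `O=C[C@H](CC(=O)O)NC(=O)[C@@H]1CC[C@@H]2C/C=C\C[C@H](NC(=O)c3nccc4ccccc34)C(=O)N21`: 188 nM

Compound 1 and compound 2 lie within the scatter of each other, while compound 3 has a lower number than compound 2, a gap beyond the scatter. Compound 4 `O=C(CN1CC=CC[C@H](NC(=O)c2ccc3ccccc3c2)C1=O)N[C@H]1CC(=O)OC1O` keeps the core of compound 2 and changes one group: naphthalen-2-yl in place of 1-benzothiophen-2-yl on a carbonyl carbon. In words, naphthalen-2-yl stands in place of 1-benzothiophen-2-yl on a carbonyl carbon. Going by the values given here, only one measured step bears on this place. That step, a 1.9-fold higher number from compound 1 to compound 2 (0.27 log units; within the scatter), exchanged 3-chlorophenyl for 1-benzothiophen-2-yl and stayed within the scatter. Among the compounds with values here, compound 3 has a different core and offers no comparable step. One step is thin evidence, but it gives no reason to expect a large shift in this assay, and no direction is favoured beyond the scatter. The expected step is a 1.3-fold lower number from compound 2 to compound 4 (0.11 log units; within the scatter), which would remain within the scatter. For compound 4 the estimated value is 550 nM, with an expected range of 220 nM to 1300 nM.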

Compound 4, half-maximal inhibitory concentration: 100 nM
Compound 4: middle estimate off by 5.5-fold (0.74 log units), on the high side; the measured number lies below the stated range.
By their numbers in this assay, from the lowest: compounds 4 and 3 (each within the scatter of the next); then compounds 1 and 2 (each within the scatter of the next).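

In this assay, going by these compounds alone, this place on the carbonyl carbon proves more sensitive than the earlier compounds suggested: naphthalen-2-yl in place of 1-benzothiophen-2-yl gives a 7.1-fold lower number from compound 2 to compound 4 (0.85 log units; beyond the scatter), and naphthalen-2-yl in place of 3-chlorophenyl gives a 3.8-fold lower number from compound 1 to compound 4 (0.58 log units; beyond the scatter). Within the data shown here, both steps lie beyond the scatter, unlike the only earlier step at this place, so two groups that each hold two aromatic rings are not interchangeable here, even though they differ only in a five-membered ring with sulfur against a six-membered ring of carbon. Nothing available accounts for this difference.

Going by these compounds, it remains open whether an amine or a carboxylic acid on the naphthalen-2-yl group would keep this number. On these data alone, it is also open how naphthalen-2-yl would behave on the core of compound 3.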